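The compounds below may be only part of what the source reports. "The series", "measured", "known", "first", "only" and "open" are said of these compounds alone.

Measured so far in an ADME assay on J774 cells (Mus musculus) for cytotoxicity, read by MTT assay, with a stated time of 48 h, tested at 100 ug/mL; a higher number here means a weaker effect of the compound at the concentration tested, a lower number a stronger effect:
compound 1 `O=C(N/N=C/c1cccc(Cl)c1)c1cnccn1` gives 100%
compound 2 `CCOc1cccc(/C=N/NC(=O)c2cnccn2)c1` gives 71%

Compound 2 holds the lower of these two numbers. For the measured compounds named here, the only measured step, a number 29 percentage points lower from compound 1 to compound 2 (beyond the scatter), is the swap of ethoxy in place of chloro on an aromatic carbon, and it moved the number by a modest amount beyond the scatter.

Compound 3 `N#Cc1cccc(/C=N/NC(=O)c2cnccn2)c1` differs from compound 2 by cyano in place of ethoxy on an aromatic carbon. Going by the values given here, no measured step involves cyano, so the size of this change can only be guessed from the one step seen: exchanging the group at this position shifted the read-out modestly, and a shift of similar size seems plausible here, with the direction uncertain. Since compound 1, which carries a small group at the same place, gave 100%, the number for compound 3 is expected to move upward, by about a number 14 percentage points higher from compound 2 to compound 3 (beyond the scatter). Compound 3 is therefore estimated at 85%, within a range from 60% to 100%.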

Compound 3, a percentage reported as activity, at one concentration (the size of the read-out at that concentration, not a potency): 100%
Compound 3: the middle estimate sits 15 percentage points below what was measured; the range from low to high includes it.
By their numbers in this assay, from the lowest: compound 2; then compounds 1 and 3 (each within the scatter of the next).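

In this assay, cyano in place of ethoxy gives a number 29 percentage points higher from compound 2 to compound 3 (beyond the scatter), so the lower number of compound 2 does not belong to the shared core alone and is tied to the ethoxy group at this place. Cyano in place of chloro gives no change at the digits printed from compound 1 to compound 3 (within the scatter), which means that two different groups, chloro and cyano, read alike here while ethoxy stands apart from both. Nothing available explains why ethoxy differs from the other two groups.

For the compounds shown here, with only three groups seen at this place, it remains open whether the stronger effect is peculiar to ethoxy. Methoxy, a longer chain such as propoxy, or an amine at the same place could show whether the number falls with other groups too.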